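The source may report more compounds than this note shows. Statements on the series, on what has been measured and on what is new or still open speak of the compounds shown alone.

Measured compounds:
Compound 1 `CC(=O)Nc1ccc(C(=O)NO)cc1` gives 270 nM in an assay on Sf9 cells for inhibition of protein deacetylase HDAC6 (Homo sapiens), read by fluorescence; a higher number here means a weaker inhibitor, a lower number a stronger inhibitor.
Compound 2 `O=C(NO)c1ccc(Cn2nnc(-c3ccc(C(F)(F)F)cc3)n2)cc1` gives 11 nM in this assay.

Compound 2 has the lower of the two numbers, and compound 1 stands far above it, well beyond the usual scatter. Compound 3 `NCc1ccc(-c2nnn(Cc3ccc(C(=O)NO)cc3)n2)cc1` has not yet been measured. It differs from compound 2 in one place: aminomethyl in place of trifluoromethyl on an aromatic carbon. For the measured compounds named here, no measured pair shows a change of this kind, so the direction is uncertain; a modest loss is expected, with the step of a 2.3-fold higher number from compound 2 to compound 3 (0.36 log units; beyond the scatter) perhaps lying within the scatter. Compound 3 is therefore estimated at 25 nM, with a range from 8 nM to 80 nM.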

Compound 3, half-maximal inhibitory concentration: 2 nM
The estimate for compound 3 lay 13-fold (1.10 log units) above the measured number; measured number outside the range, below it.
By their numbers in this assay, from the lowest: compound 3; then compound 2; then compound 1.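

Putting aminomethyl in place of trifluoromethyl on this aromatic carbon, para to a large group, gives a 5.5-fold lower number from compound 2 to compound 3 (0.74 log units; beyond the scatter) in this assay. This single step shows that the position accepts a group with a nitrogen and that the change can strengthen inhibition. The entering group carries a hydrogen-bond donor and acceptor and trifluoromethyl carries neither, but nothing available here shows what lies behind the difference. Still open, going by these compounds, is how a plain amine, a longer chain such as aminoethyl, or a carboxylic acid would fare at this carbon.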